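Working notes: carbamoyl to nitro, compound 3 to compound 4

The compounds below may be only part of what the source reports. "The series", "measured", "known", "first", "only" and "open" are said of these compounds alone.

- compound 1 `COc1ccc(NC(=O)Nc2cc(C)nc3ccccc23)cc1OC`: > 25000 nM, a limit
- compound 2 `Cc1cc(NC(=O)Nc2ccccc2C(C)(C)C)c2ccccc2n1`: > 25000 nM, a limit
- compound 3 `Cc1cc(NC(=O)Nc2ccccc2C(N)=O)c2ccccc2n1`: > 25000 nM, a limit

All three entries come from an ADME assay on HepG2 cells (Homo sapiens) for cytotoxicity, with a stated time of 72 h (a lower number here means that less compound is needed, a higher number that more compound is needed for the effect), and none of them is a number. In this assay, from the compounds shown here alone, compound 3 gives > 25000 nM, which is a limit of the assay, so its true position remains unknown.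

The next compound is compound 4 `Cc1cc(NC(=O)Nc2ccccc2[N+](=O)[O-])c2ccccc2n1`, which carries nitro in place of carbamoyl on an aromatic carbon.

Going by the values given here, one measured step bears on this same place: a step that the two limits leave unreadable from compound 2 to compound 3. Its size cannot be read, so it offers no measure of how far a change here can move the result. The remaining guide is the limit of > 25000 nM in this assay, at which 3 of the 3 values shown sit, which covers compound 1, compound 2 and compound 3 alike. On that basis compound 4 is expected to stay with them, and a report of only a limit is the likeliest outcome.

The expected step is a number no higher from compound 3 to compound 4 (the limit leaves the size open), with nothing beyond the scatter and no direction foreseen. The estimate for compound 4 is 25000 nM, with an expected range of 10000 nM to 40000 nM.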

Compound 4, half-maximal effective concentration: > 25000 nM
Compound 4: a limit, no number (the forecaster's own chance of this, stated with the estimate: 80%); the middle value lies on the limit itself.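

In this assay compound 4 gives > 25000 nM, a limit and not a number, so no step can be read from compound 2 or compound 3 to compound 4. The compounds shown leave open whether nitro, carbamoyl and tert-butyl differ at all on this aromatic carbon, with every result resting on one reading: the limit of > 25000 nM in this assay, at which 4 of the 4 values shown sit.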